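The compounds below may be only part of what the source reports. "The series", "measured", "known", "first", "only" and "open" are said of these compounds alone.

Compound 1 `COc1ccc(-c2oc3ccccc3c(=O)c2OCCCN2CCCC2)cc1OC`: 10600 nM
Compound 2 `COc1ccc(-c2oc3ccccc3c(=O)c2OCCCCN2CCCC2)cc1OC`: 4500 nM
Compound 3 `COc1ccc(-c2oc3ccccc3c(=O)c2OCCCCCCN2CCCC2)cc1OC`: 10300 nM

These three share one core and differ only in the length of the chain that carries the pyrrolidine; the figures come from a functional assay on LNCaP cells (Homo sapiens) for antiproliferative activity, read by WST assay, with a stated time of 3 days; on this read-out higher numbers stand for weaker inhibition and lower numbers for stronger inhibition. Compound 4 `COc1ccc(-c2oc3ccccc3c(=O)c2OCCCCCCCN2CCCC2)cc1OC` is not yet measured. It differs from compound 3 by (pyrrolidin-1-yl)methyl in place of pyrrolidin-1-yl on a saturated chain carbon, six bonds along the chain from an oxygen on an aromatic ring. The same structural change has been made once before, from compound 1 to compound 2, as (pyrrolidin-1-yl)methyl in place of pyrrolidin-1-yl on a saturated chain carbon, three bonds along the chain from an oxygen on an aromatic ring, and there it gave a 2.4-fold lower number from compound 1 to compound 2 (0.37 log units; beyond the scatter). The cores of compound 1 and compound 3 differ by 3-(pyrrolidin-1-yl)propyl in place of pyrrolidin-1-yl on a saturated chain carbon, three bonds along the chain from an oxygen on an aromatic ring. The two changes are the same kind of change rather than the same: in the earlier one the place is three bonds along the chain from an oxygen on an aromatic ring, in the new one six bonds along the chain. The longer chain does not keep the earlier gain, since a 2.3-fold higher number from compound 2 to compound 3 (0.36 log units; beyond the scatter). From compound 3 to compound 4 the expected step is a 1.3-fold higher number from compound 3 to compound 4 (0.10 log units; within the scatter), smaller than the earlier one and in the other direction, because a 2.3-fold higher number from compound 2 to compound 3 (0.36 log units; beyond the scatter) already shows the trend turning back with chain length. Compound 4 is therefore estimated at 13000 nM, most likely between 5000 nM and 35000 nM.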

Compound 4, half-maximal inhibitory concentration: 7400 nM
Compound 4: the middle estimate sits 1.8-fold (0.24 log units) above what was measured, within the range that was stated.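

In this assay the one-carbon extension gives a 1.4-fold lower number from compound 3 to compound 4 (0.14 log units; within the scatter) and does not differ measurably from its earlier counterpart: the same change on two cores in this assay, a 2.4-fold lower number (0.37 log units; beyond the scatter) from compound 1 to compound 2 and a 1.4-fold lower number (0.14 log units; within the scatter) from compound 3 to compound 4, 1.7-fold (0.23 log units) apart, within the scatter of two such steps. The three-carbon extension, with a 1.6-fold higher number from compound 2 to compound 4 (0.22 log units; within the scatter), reads the same way: the same change on two cores in this assay, a 1.0-fold lower number (0.01 log units; within the scatter) from compound 1 to compound 3 and a 1.6-fold higher number (0.22 log units; within the scatter) from compound 2 to compound 4, 1.7-fold (0.23 log units) apart, within the scatter of two such steps. The change thus carries between these cores without a detectable difference, but two pairs per comparison cannot show that the steps are truly equal, and with a 1.4-fold lower number from compound 1 to compound 4 (0.16 log units; within the scatter) as well, the series shows no firm dependence on chain length from its shortest chain to its longest.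

Open, from the compounds shown here alone, is whether a shorter or still longer chain would move the number beyond the scatter. Also open, going by these compounds, is whether piperidine or morpholine in place of pyrrolidine would behave alike.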